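This account rests on a few compounds, and the source may have more. Where it says the series, first, only, none or still open, it means among the compounds named here.

Compound 1 `COc1cc(Cc2nc3c(N)ncnc3n2CCCC(C)C)cc(OC)c1OC` belongs to a set of three related compounds tested in a functional assay on MCF7 cells (Homo sapiens) for antiproliferative activity; on this read-out lower numbers stand for stronger inhibition and higher numbers for weaker inhibition. In this assay compound 1 gives 69200 nM, the highest of the three numbers. Compound 2 `CC[C@H](C)Cn1c(Cc2cc(OC)c(OC)c(OC)c2)nc2c(N)nc(F)nc21` gives 43700 nM, which lies within the scatter of compound 1. Compound 3 `COc1cc(Cc2nc3c(N)nc(F)nc3n2CC2CCCO2)cc(OC)c1OC` gives 22900 nM, and its gap to compound 1 lies beyond the scatter. Compounds 2 and 3 each differ from compound 1 in more than one place, so their numbers can only be set beside it, not read as a single step.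

Compound 4 `C/C=C/Cn1c(Cc2cc(OC)c(OC)c(OC)c2)nc2c(N)ncnc21` has not yet been measured. It differs from compound 1 in one place: prop-1-en-1-yl in place of isopentyl on a saturated chain carbon bound to an aromatic nitrogen. Among the compounds with values here, the only measured step that changes a group at this same place is a 1.9-fold lower number from compound 2 to compound 3 (0.28 log units; within the scatter), and it stayed within the scatter. Because a 1.9-fold lower number from compound 2 to compound 3 (0.28 log units; within the scatter) shows that swapping the group on this carbon moved the number little, only a small step is expected from compound 1 to compound 4 in this assay, roughly a 1.3-fold lower number from compound 1 to compound 4 (0.10 log units; within the scatter), with no firm direction. Compound 4 is therefore estimated at 55000 nM, with a likely range from 20000 nM to 150000 nM.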

Compound 4, half-maximal inhibitory concentration: 51300 nM
For compound 4 the middle estimate is 1.1-fold (0.03 log units) above the measured one, and the stated range covers the measured number.
By their numbers in this assay, from the lowest: compounds 3, 2, 4 and 1 (each within the scatter of the next, the first and the last beyond it).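

In this assay, a single change made directly on the core of compound 1 gives a 1.3-fold lower number from compound 1 to compound 4 (0.13 log units; within the scatter). Here isopentyl, with 5 heavy atoms and no double bond, gives way to prop-1-en-1-yl, with 3 heavy atoms and a double bond outside aromatic rings, so a shorter and unsaturated group on a saturated chain carbon bound to an aromatic nitrogen leaves the number within the scatter of compound 1. Set beside a 1.9-fold lower number from compound 2 to compound 3 (0.28 log units; within the scatter), which brought in oxolan-2-yl in place of sec-butyl on a different core, this is a second swap at this place that stays within the scatter, now with a group made only of carbon.

Nothing available offers a cause for this flat response at this place. Still open, on these data alone, is whether a group of another kind here, such as an amine or a carboxylic acid, would move the number beyond the scatter, and whether prop-1-en-1-yl would give a similar step on the core shared by compound 2 and compound 3.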